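Hydrazone aryl swap on the shared core, toward compound 3

The source may hold more compounds than are shown below. What is called first, only, known or untested is meant among the compounds shown, and "the series" means these compounds.

Compound 1 `Cn1c(=O)c(=O)n(C2CCCC2)c2nc(N/N=C/c3cccs3)ncc21` carries a thiophen-2-yl on the hydrazone carbon. Among the measured compounds shown here, in a functional assay on HCT-116 cells (Homo sapiens) for antiproliferative activity, read by MTT assay (on this read-out higher numbers stand for weaker inhibition and lower numbers for stronger inhibition), compound 1 gives 52600 nM, the highest of the two numbers measured so far. For the measured compounds named here, the only measured step that bears on the present change is the one to compound 2 `Cn1c(=O)c(=O)n(C2CCCC2)c2nc(N/N=C/c3cc([N+](=O)[O-])ccc3Cl)ncc21`, where compound 2 gives 5610 nM in this assay, a change of a 9.4-fold lower number from compound 1 to compound 2 (0.97 log units; beyond the scatter).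

Compound 3 `Cn1c(=O)c(=O)n(C2CCCC2)c2nc(N/N=C/c3ccc(F)cc3F)ncc21` differs from compound 1 by 2,4-difluorophenyl in place of thiophen-2-yl on a carbon with a double bond to nitrogen. As far as these compounds go, this is again a six-membered carbon-only aromatic ring entering in place of the thiophen-2-yl, as in the step to compound 2, so a lower number is expected, though a smaller one, since the fluorine substitution pattern is untested here.

For compound 3 a value of 18000 nM is estimated in this assay, with a range of 5000 nM to 60000 nM, meaning an expected step of a 2.9-fold lower number from compound 1 to compound 3 (0.47 log units; beyond the scatter).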

Compound 3, half-maximal inhibitory concentration: 19800 nM
For compound 3 the middle estimate is 1.1-fold (0.04 log units) below the measured one; measured number inside the range.
By their numbers in this assay, from the lowest: compound 2; then compound 3; then compound 1.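

In this assay the 2,4-difluorophenyl gives a 2.7-fold lower number from compound 1 to compound 3 (0.42 log units; beyond the scatter) and so also falls below the thiophen-2-yl, which means the direction seen with compound 2 is not confined to a single six-membered carbon-only aromatic ring. The position also separates the two substituted rings, with a 3.5-fold higher number from compound 2 to compound 3 (0.55 log units; beyond the scatter) placing the 2-chloro-5-nitrophenyl lowest of the three, so the number depends on the substituents as well as on the ring. Nothing available here explains either step.

Open, as far as these compounds go, is how each substituent contributes, since chlorine and nitro appear only together, as do the two fluorines. A single amine or carboxylic acid on the six-membered ring, or a pyridine ring in its place, would show how far this trend extends across the series.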